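Swapping a benzyloxy oxime ether for a hydroxypropoxy chain

The source may report more compounds than this note shows. Statements on the series, on what has been measured and on what is new or still open speak of the compounds shown alone.

Compound 3 `Nc1ncnc(Oc2ccc(NC(=O)C3(C(=O)Nc4ccc(F)cc4)CC3)cc2F)c1/C=N/OCc1ccccc1` is the most lipophilic of the three measured compounds in a physicochemical assay for lipophilicity, using the shake flask method (a higher number here means a more lipophilic compound, a lower number a more polar compound), where compound 3 gives 4.45. Compound 1 `CC(C)(C)OC(=O)N/N=C/c1c(N)ncnc1Oc1ccc(NC(=O)C2(C(=O)Nc3ccc(F)cc3)CC2)cc1F` gives 3.7, and compound 2 `CC(O)CO/N=C/c1c(N)ncnc1Oc1ccc(NC(=O)C2(C(=O)Nc3ccc(F)cc3)CC2)cc1F` gives 2.75; the shift was a number 0.75 log units higher from compound 1 to compound 3 (beyond the scatter) and, most relevant here, a number 1.70 log units higher from compound 2 to compound 3 (beyond the scatter). Compound 4 `Nc1ncnc(Oc2ccc(NC(=O)C3(C(=O)Nc4ccc(F)cc4)CC3)cc2F)c1/C=N/OCCCO` reverses that last kind of change: 2-hydroxyethyl in place of phenyl on a saturated chain carbon bound to an oxygen. Since the step from compound 2 to compound 3 was large, and the hydroxylated chain of compound 4 resembles that of compound 2, a drop of similar size is expected, a number 1.75 log units lower from compound 3 to compound 4 (beyond the scatter). Compound 4 is therefore estimated at 2.7 in this assay, with a range of 2.3 to 3.1.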

Compound 4, partition coefficient: 2.67
Compound 4: the middle estimate sits 0.03 log units above what was measured, and the stated range covers the measured number.
By their numbers in this assay, from the lowest: compounds 4 and 2 (each within the scatter of the next); then compound 1; then compound 3.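

A second hydroxylated chain repeats the fall seen with compound 2: the shift of a number 1.78 log units lower from compound 3 to compound 4 (beyond the scatter) in this assay shows that the large gap from the benzyloxy group is not confined to one chain. The shift of a number 0.08 log units lower from compound 2 to compound 4 (within the scatter) means that 2-hydroxyethyl and 1-hydroxyethyl cannot be told apart at this place in this assay here. The shift of a number 1.03 log units lower from compound 1 to compound 4 (beyond the scatter) puts the 3-hydroxypropoxy chain on the same side of the (tert-butoxycarbonyl)amino group as the 2-hydroxypropoxy chain.

From the compounds shown here alone, whether an amine, a carboxylic acid or a longer chain carrying the hydroxyl would read like these chains stays open. Nothing shown accounts for these shifts.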